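This account rests on a few compounds, and the source may have more. Where it says the series, first, only, none or still open, it means among the compounds named here.

Compound 1 `Cc1ccsc1/C=C(/SCc1ccc(F)cc1)C(=O)c1ccc(Br)cc1`: 50000 nM
Compound 2 `Cc1ccc(S/C(=C/c2sccc2C)C(=O)c2ccc(Br)cc2)cc1`: 50000 nM

Among the measured compounds shown here, in a functional assay on DU-145 cells (Homo sapiens) for inhibition, read by trypan blue exclusion, with a stated time of 96 h (a higher number here means a weaker inhibitor of growth, a lower number a stronger inhibitor of growth), compound 1 gives 50000 nM and stands level with compound 2, which gives 50000 nM; the one measured step, no change at the digits printed from compound 1 to compound 2 (within the scatter), changes a sulfur substituent and so does not touch the part altered in compound 3 `O=C(/C(=C\c1c[nH]c2ccc(Cl)cc12)SCc1ccc(F)cc1)c1ccc(Br)cc1`. The change from compound 1 to compound 3 is 5-chloro-1H-indol-3-yl in place of 3-methylthiophen-2-yl on a double-bonded chain carbon bound to a double-bonded chain carbon. For the measured compounds named here, no measured step bears on this position, so the estimate leans on the two measured values alone. Compound 3 is expected to give 30000 nM, within 8000 nM to 60000 nM, a step of a 1.7-fold lower number from compound 1 to compound 3 (0.22 log units; within the scatter) that is expected to stay near the scatter.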

Compound 3, concentration for 50% growth inhibition: 1000 nM
Beside the measured number, compound 3's estimate is 30-fold (1.48 log units) above it; the measured number lies below the stated range.
By their numbers in this assay, from the lowest: compound 3; then compounds 1 and 2 (each within the scatter of the next).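

In this assay, the group on a double-bonded chain carbon bound to a double-bonded chain carbon proves to matter, which the sulfur change had not shown: 5-chloro-1H-indol-3-yl in place of 3-methylthiophen-2-yl gives a 50-fold lower number from compound 1 to compound 3 (1.70 log units; beyond the scatter), a large step. No evidence is available to explain this step. The compounds shown leave open whether the chlorine, the ring nitrogen hydrogen or the added six-membered ring carries the step, and whether a methoxy group could stand in for the chlorine. Going by these compounds, whether the 4-methylphenyl on sulfur of compound 2 would fit 5-chloro-1H-indol-3-yl equally also remains open.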